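The source may hold more compounds than are shown below. What is called first, only, known or untested is meant among the compounds shown, and "the series" means these compounds.

Measured so far:

Compound 1, `O=C(Nc1ccc(I)cc1F)c1cc(Cl)ccc1O`, in an ADME assay on RAW264.7 cells (Mus musculus) for cytotoxicity, read by MTT assay, with a stated time of 24 h (on this read-out lower numbers stand for higher toxicity in this test and higher numbers for lower toxicity in this test), gives 7600 nM.
Compound 2, `O=C(Nc1ccc(Cl)cc1F)c1cc(Br)ccc1O`, in this assay gives 9200 nM.

Compound 2 stands at the highest of the two numbers recorded in this assay, but the nearest value, that of compound 1, lies within the scatter of the method, so the two measured compounds show no separation on this read-out. Both carry a halogen on each of the two rings of the shared core and differ in which halogen sits where, and neither arrangement is distinguishable from the other here.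

Compound 3, `O=C(Nc1ccc(I)cc1F)c1cc(Br)ccc1O`, is not yet measured. Against compound 2 the change is iodo in place of chloro on an aromatic carbon. Going by the values given here, the same iodo group on that ring is already present in compound 1, whose value in this assay sits within the scatter of compound 2, and no single-change step between measured compounds is available to calibrate the exchange. No step beyond the scatter is therefore expected in this assay, in either direction.

Compound 3 is estimated at 8000 nM in this assay, with a range of 4000 nM to 16000 nM. This estimate means an expected step of a 1.2-fold lower number from compound 2 to compound 3 (0.06 log units; within the scatter).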

Compound 3, half-maximal cytotoxic concentration: 6400 nM
Compound 3: middle estimate off by 1.3-fold (0.10 log units), on the high side; low and high end bracket the measured number.
By their numbers in this assay, from the lowest: compounds 3, 1 and 2 (each within the scatter of the next).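

In this assay, going by these compounds alone, iodo in place of chloro on the aromatic carbon meta to a fluoro group and para to a large group gives a 1.4-fold lower number from compound 2 to compound 3 (0.16 log units; within the scatter) and provides the first single-change reading at this position, where exchanging these two halogens does not separate the compounds on this read-out. With iodo held on that ring, exchanging chloro for bromo on the other ring gives a 1.2-fold lower number from compound 1 to compound 3 (0.07 log units; within the scatter) and so adds a second single-change reading, at a different place, which is also not separated from the scatter. Both halogen exchanges therefore leave the three compounds indistinguishable in this test, and no supporting measurement bears on either result.

All of the exchanges shown are between halogens at these two places, so the compounds leave open whether a group of another kind there, such as an amine, a methoxy group or a carboxylic acid, would give a step beyond the scatter. They also leave open what the read-out would show with the halogen at either place replaced by hydrogen, or with a change elsewhere on the shared core.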